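Methylsulfanyl for Methyl: What Compound 4 Is Expected to Show

This account rests on a few compounds, and the source may have more. Where it says the series, first, only, none or still open, it means among the compounds named here.

Of the compounds shown here, three built on one shared core have been tested in an ADME assay on HEL cells (Homo sapiens) for cytotoxicity; a higher number here means that more compound is tolerated, a lower number that less compound is tolerated. Compound 1 `Cc1ccc(/C=N/NC(=O)COc2cccc3ccccc23)cc1` gives 20 ug/mL. Compound 2 `C/C(=N\NC(=O)COc1cccc2ccccc12)c1ccc(Br)cc1` gives 20 ug/mL in this assay, and compound 3 `C/C(=N\NC(=O)COc1cccc2ccccc12)c1cccc([N+](=O)[O-])c1` gives 20 ug/mL. Among the compounds with values here, compound 1 thus stands level with compounds 2 and 3, and the one measured step, no change at the digits printed from compound 2 to compound 3 (within the scatter), lies within the scatter. Compound 4 `CSc1ccc(/C=N/NC(=O)COc2cccc3ccccc23)cc1` differs from compound 1 in a single place: methylsulfanyl in place of methyl on an aromatic carbon. Within the data shown here, no measured step touches the same place; the step from 4-bromophenyl to 3-nitrophenyl swaps a substituent on a ring of the same kind and left the read-out where it was. The data therefore give no sign that a substituent on this ring moves cytotoxicity. For compound 4 the expected step is no change at the digits printed from compound 1 to compound 4 (within the scatter), nothing beyond the scatter, because no change at the digits printed from compound 2 to compound 3 (within the scatter) showed none either. The estimate for compound 4 in this assay is 20 ug/mL, with a range from 10 ug/mL to 40 ug/mL.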

Compound 4, minimum cytotoxic concentration: >= 100 ug/mL
Compound 4: no number, only a limit (the forecaster's own chance of this, stated with the estimate: 15%); middle value at least 5.0-fold (0.69 log units) away from the limit.
By their numbers in this assay, from the lowest: compounds 1, 2 and 3 (each within the scatter of the next). At a limit, above all of these: compound 4.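

In this assay, methylsulfanyl in place of methyl on an aromatic carbon, para to a large group, gives an at least 5.0-fold higher number from compound 1 to compound 4 (0.69 log units; beyond the scatter). Within the data shown here, the earlier compounds offered only no change at the digits printed from compound 2 to compound 3 (within the scatter), so this is the first sign that a change on this ring can move the read-out, and it does so with nothing else in the structure altered. The read-out for compound 4 is a limit of the assay, not a number: the limit of >= 100 ug/mL in this assay, at which 1 of the 4 values shown sits.

Going by these compounds, whether the step depends on the sulfur atom or on the larger group stays open, and a methoxy group or an ethyl chain in the same place would separate the two. Also open, on these data alone, is whether methylsulfanyl gives a like step on the core of compounds 2 and 3, which carry a methyl group on the carbon with a double bond to nitrogen.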